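A Methoxy-to-Hydrogen Swap on Two Related Cores

A few compounds are considered here, and "the series" means these few. Any claim that something is new, unique, unknown or untested is made for them only; others in the source may bear on it.

Compound 1 `COc1cc(/C=C/C(=O)/C=C(O)/C=C/c2ccc(O[C@]3(C)C=C[C@@H]([C@@H](C)CC(=O)C=C(C)C)C[C@@H]3O)c(OC)c2)ccc1O` gives 15200 nM in a functional assay on A549 cells (Homo sapiens) for cytotoxicity, read by crystal violet staining, with a stated time of 72 h; on this read-out lower numbers stand for stronger inhibition and higher numbers for weaker inhibition. Compound 2 `COc1cc(/C=C/C(=O)/C=C(O)/C=C/c2ccc(O[C@]3(C)C=C[C@@H]([C@@H](C)CC(=O)C=C(C)C)C[C@@H]3O)cc2)ccc1O`, which carries hydrogen in place of methoxy on an aromatic carbon, gives 14500 nM in this assay, which is a 1.0-fold lower number from compound 1 to compound 2 (0.02 log units; within the scatter). Compound 3 `COc1cc(/C=C/C(O)=C/C(=O)/C=C/c2ccc(O)cc2)ccc1O[C@H]1C=C(C)[C@@H](O)C[C@@H]1[C@@H](C)CC(=O)C=C(C)C` gives 16600 nM in this assay; the difference between its core and the core of compound 1 is not broken down here. Compound 4 `CC(C)=CC(=O)C[C@H](C)[C@H]1C[C@H](O)C(C)=C[C@@H]1Oc1ccc(/C=C/C(O)=C/C(=O)/C=C/c2ccc(O)cc2)cc1` has not yet been measured. It differs from compound 3 by hydrogen in place of methoxy on an aromatic carbon, the same change, at the same place, as that made from compound 1 to compound 2. Because that earlier step was a 1.0-fold lower number from compound 1 to compound 2 (0.02 log units; within the scatter), the expected step here is a 1.0-fold lower number from compound 3 to compound 4 (0.02 log units; within the scatter), likewise within the scatter. Compound 4 is therefore estimated at 16000 nM, expected to fall between 8000 nM and 32000 nM.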

Compound 4, half-maximal inhibitory concentration: 27400 nM
For compound 4 the middle estimate is 1.7-fold (0.23 log units) below the measured one; measured number inside the range.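

In this assay, the same swap of methoxy for hydrogen on the second core gives a 1.7-fold higher number from compound 3 to compound 4 (0.22 log units; within the scatter). Set beside the earlier step, the swap reads the same on both cores once the usual scatter is allowed for: the same change on two cores in this assay, a 1.0-fold lower number (0.02 log units; within the scatter) from compound 1 to compound 2 and a 1.7-fold higher number (0.22 log units; within the scatter) from compound 3 to compound 4, 1.7-fold (0.24 log units) apart, within the scatter of two such steps. This shows that, in these two pairs, the swap moves the number by no more than the scatter on either core, but two pairs in one assay do not show that this holds on other cores of the series, and they give no reason for it.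

The compounds shown carry only methoxy or hydrogen at this place. On these data alone, what an ethoxy group, a fluorine atom or an amine would do there stays open.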